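The source may hold more compounds than are shown below. What is called first, only, known or untested is meant among the compounds shown, and "the series" means these compounds.

Working notes on the series. For the measured compounds named here, in a physicochemical assay for solubility, read by HPLC, in phosphate buffer, measured as kinetic solubility, with a stated time of 1 h, at pH 7.4, tested at 250 uM (on this read-out lower numbers stand for lower solubility and higher numbers for higher solubility), compound 1 `CN1CCC(c2ccc3c(c2)oc(=O)n3C(=O)NCCCCc2ccccc2)CC1=O` gives 20000 nM, and this is the only numerical value shown for this read-out. Compound 2 `CCCCCNC(=O)n1c(=O)oc2cc(-c3ccc(F)cc3)ccc21` gives in this assay < 1000 nM, which is a limit of the assay and not a number (the limit of < 1000 nM in this assay, at which 1 of the 2 values shown sits). No step between two measured compounds that differ in one place is shown, so no measured size of change in solubility is available.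

Compound 3 `CN1CCN(c2ccc3c(c2)oc(=O)n3C(=O)NCCCCc2ccccc2)C(=O)C1` has not yet been measured in this assay. It differs from compound 1 by 4-methyl-2-oxopiperazin-1-yl in place of 1-methyl-2-oxopiperidin-4-yl on an aromatic carbon. The place of the change is an aromatic carbon of the carbon-only six-membered aromatic ring of the fused two-ring core, meta and para to a fused ring.

Going by the values given here, with no measured step to lean on, the expected change in this assay, a 1.5-fold higher number from compound 1 to compound 3 (0.18 log units; within the scatter), is estimated as small, toward higher solubility, and not clearly beyond the scatter. The estimated value for compound 3 in this assay is 30000 nM, with an expected range from 12000 nM to 80000 nM.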

Compound 3, solubility: 20000 nM
For compound 3 the middle estimate is 1.5-fold (0.18 log units) above the measured one; the measured number falls inside the stated range.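

At this aromatic carbon, meta to a fused ring and para to a fused ring, the series now has its first measured step in this assay: no change at the digits printed from compound 1 to compound 3 (within the scatter). The two groups match in heavy atoms, while 4-methyl-2-oxopiperazin-1-yl brings 2 hetero atoms in its ring against 1 in 1-methyl-2-oxopiperidin-4-yl, and this exchange comes with no measured movement in the read-out. Nothing measured here gives a reason for that outcome.

For the compounds shown here, whether an open-chain amine or a carboxylic acid on the same aromatic carbon would shift the number remains open, as only one ring exchange can be read at this position. Compound 2 carries a limit of the assay, not a number, and differs from the others in more than one place, so it adds no step: the limit of < 1000 nM in this assay, at which 1 of the 3 values shown sits.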